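Swapping the hydroxypiperidine amide for a piperazine amide

The compounds below may be only part of what the source reports. "The series", "measured", "known", "first", "only" and "open" are said of these compounds alone.

Compound 1 `CC(C)(C)c1ccc(C(=O)N2CCC3(CC2)C(=O)N(CC(=O)NCCC(=O)O)CN3c2ccccc2)cc1`: 11400 nM
Compound 2 `CC(C)(C)c1ccc(C(=O)N2CCC3(CC2)C(=O)N(CC(=O)NCN)CN3c2ccccc2)cc1`: 26500 nM
Compound 3 `CC(C)(C)c1ccc(C(=O)N2CCC3(CC2)C(=O)N(CC(=O)N2CCC(O)CC2)CN3c2ccccc2)cc1`: 4700 nM

All three compounds share one core and differ only in the group attached to the carbonyl carbon at the end of the side chain. In an assay on HEK293 cells for displacement of a labelled ligand from NPC1-like intracellular cholesterol transporter 1 (Homo sapiens) (on this read-out higher numbers stand for weaker inhibition and lower numbers for stronger inhibition), compound 3 gives 4700 nM, the lowest number of the three. The step of a 2.4-fold lower number from compound 1 to compound 3 (0.38 log units; beyond the scatter) and the step of a 5.6-fold lower number from compound 2 to compound 3 (0.75 log units; beyond the scatter) both lie beyond the usual scatter, so compound 3 is the strongest of the measured set. Compound 2, which carries an amino group on that chain, shows the highest number, as the step of a 2.3-fold higher number from compound 1 to compound 2 (0.37 log units; beyond the scatter) records.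

Compound 4 `CC(C)(C)c1ccc(C(=O)N2CCC3(CC2)C(=O)N(CC(=O)N2CCNCC2)CN3c2ccccc2)cc1` is not yet measured. Its change is piperazin-1-yl in place of 4-hydroxypiperidin-1-yl on a carbonyl carbon. Going by the values given here, no measured step touches this exact swap. Among the compounds with values here, the only guidance is that compound 3 holds the best number and that the other two amide variants, compound 1 and compound 2, both sit higher. On that basis compound 4 is expected to show a somewhat higher number than compound 3, a step of about a 1.7-fold higher number from compound 3 to compound 4 (0.23 log units; within the scatter) in this assay, though a result within the scatter would not be surprising. The estimate for compound 4 is 8000 nM, with a range from 2500 nM to 25000 nM.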

Compound 4, half-maximal inhibitory concentration: 22000 nM
For compound 4 the middle estimate is 2.8-fold (0.44 log units) below the measured one; low and high end bracket the measured number.
By their numbers in this assay, from the lowest: compound 3; then compounds 1, 4 and 2 (each within the scatter of the next, the first and the last beyond it).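

In this assay the step of a 4.7-fold higher number from compound 3 to compound 4 (0.67 log units; beyond the scatter) shows that this position on the carbonyl carbon responds to a small change: the ring stays six-membered and the counted hydrogen-bond donors and acceptors stay the same, yet the swap of 4-hydroxypiperidin-1-yl for piperazin-1-yl is still read beyond the scatter. The ring amide of compound 4 also cannot be told apart from the open-chain amides, since the step of a 1.2-fold lower number from compound 2 to compound 4 (0.08 log units; within the scatter) and the step of a 1.9-fold higher number from compound 1 to compound 4 (0.29 log units; within the scatter) both stay within the scatter, which leaves compound 3 alone in holding a lower number than compound 4. Nothing available here accounts for the difference between these two rings.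

The compounds shown leave open whether the hydroxyl group, the second ring nitrogen or both set the size of this step, a question that plain piperidin-1-yl, with neither feature, could help to answer. They also leave open how morpholin-4-yl, with a ring oxygen, or 4-methylpiperazin-1-yl, with a methyl group on the ring nitrogen, would read at this same position.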